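This account rests on a few compounds, and the source may have more. Where it says the series, first, only, none or still open, it means among the compounds named here.

Measured in an ADME assay on microsomes from liver (Homo sapiens) for metabolic stability, with a stated time of 10 min; a higher number here means that more of the compound is left, a lower number that less of the compound is left:
Compound 1 (`Fc1ccccc1-c1ccc2[nH]c(C3=NOC4(CCCCC4)C3)nc2c1`) gives 79%
Compound 2 (`Fc1ccccc1-c1cc(C(F)(F)F)c2[nH]c(C3=NOC4(CCCCC4)C3)nc2c1`) gives 71%

Among the measured compounds shown here, these are the only two numbers, and compound 1 stands level with compound 2 within the scatter. Compound 3 (`CC(C)(O)c1ccccc1-c1ccc2[nH]c(C3=NOC4(CCCCC4)C3)nc2c1`) differs from compound 1 by 1-hydroxy-1-methylethyl in place of fluoro on an aromatic carbon. Only compound 2 offers a measured step (a number 8 percentage points lower from compound 1 to compound 2 (within the scatter)), and that step is a different change, trifluoromethyl in place of hydrogen, so it is weak guidance. No step beyond the scatter is expected in this assay, though a slightly lower number is expected (a number 7 percentage points lower from compound 1 to compound 3 (within the scatter)). Compound 3 is expected at 72% (estimated range 50% to 90%).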

Compound 3, percent of the compound remaining: 44%
Beside the measured number, compound 3's estimate is 28 percentage points above it; the measured number lies below the stated range.
By their numbers in this assay, from the lowest: compound 3; then compounds 2 and 1 (each within the scatter of the next).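

In this assay, this aromatic carbon, ortho to a large group, proves sensitive to what it carries: 1-hydroxy-1-methylethyl in place of fluoro gives a number 35 percentage points lower from compound 1 to compound 3 (beyond the scatter) and so moves the number well beyond the scatter. Among the compounds shown here, the only earlier step, trifluoromethyl in place of hydrogen at another carbon, stayed within the scatter and showed no such sensitivity. Nothing available explains the fall. On these data alone, whether a tert-butyl group, a methoxy group or an amine at this carbon would fall as far remains open. So does whether 1-hydroxy-1-methylethyl would act the same alongside the trifluoromethyl of compound 2.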